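The source may hold more compounds than are shown below. What is called first, only, known or untested is meant among the compounds shown, and "the series" means these compounds.

Measured compounds, an assay on cells for inhibition of serine/threonine-protein kinase WNK1 (Homo sapiens), read by luminescence and Kinase-Glo, with a stated time of 2 h; on this read-out lower numbers stand for stronger inhibition and higher numbers for weaker inhibition:

Compound 1 `O=[N+]([O-])c1cc(S(=O)(=O)C(Cl)(Cl)Br)ccc1Nc1ccccc1` gives 76000 nM.
Compound 2 `O=[N+]([O-])c1cc(S(=O)(=O)C(Cl)(Cl)Br)ccc1NC1CCCC1` gives 93000 nM.

Compound 2 holds the highest of the two numbers; its nearest neighbour is compound 1, and the step of a 1.2-fold higher number from compound 1 to compound 2 (0.09 log units; within the scatter) lies within the scatter, so the two compounds cannot be told apart in this assay .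

Compound 3 `CN1CCN(c2ccc(S(=O)(=O)C(Cl)(Cl)Br)cc2[N+](=O)[O-])CC1` is the next compound to be measured. It differs from compound 2 by 4-methylpiperazin-1-yl in place of cyclopentylamino on an aromatic carbon. Among the measured compounds shown here, the only step in the set, a 1.2-fold higher number from compound 1 to compound 2 (0.09 log units; within the scatter), exchanges one group on the same position for another and was within the scatter; it is the one precedent that bears on this change, and it gives no ground for expecting a shift beyond the scatter. The expected step is therefore a 1.0-fold lower number from compound 2 to compound 3 (0.01 log units; within the scatter), with no direction favoured. For the measured compounds named here, the estimate for compound 3 in this assay is 90000 nM, with the range 30000 nM to 300000 nM, kept wide because no other step involves a saturated ring with hetero atoms.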

Compound 3, half-maximal inhibitory concentration: > 1000000 nM
Compound 3 gave a limit, no number; the forecaster's own chance of this, stated with the estimate: 30%; at least 11-fold (1.04 log units) between middle value and limit.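

The reading for compound 3 in this assay is a limit, not a number: the limit of > 1000000 nM in this assay, at which 1 of the 3 values shown sits. Anilino and cyclopentylamino could not be told apart, but this position, para to the (bromo(dichloro)methyl)sulfonyl group and ortho to the nitro group, does respond to the choice of group: 4-methylpiperazin-1-yl gives an at least 10-fold higher number from compound 2 to compound 3 (1.03 log units; beyond the scatter) and an at least 13-fold higher number from compound 1 to compound 3 (1.11 log units; beyond the scatter). Against cyclopentylamino, the exchange alters the ring size, the hetero atoms and the hydrogen-bond donor count together, so these steps cannot assign the weakening to any one of these.

A piperidin-1-yl group would separate the second ring nitrogen from the loss of the amino hydrogen, while a 2-(dimethylamino)ethylamino chain would keep that hydrogen alongside a second nitrogen. On these data alone, whether any group at this position gives a clearly lower number than anilino or cyclopentylamino remains open.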